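Swapping bromo for nitro on the thioether phenyl ring

The compounds below may be only part of what the source reports. "The series", "measured", "known", "first", "only" and "open" are said of these compounds alone.

Of the compounds shown here, three built on one shared core have been measured in an assay on isolated protein for binding affinity to Equilibrative nucleoside transporter 1 (Homo sapiens); a higher number here means a weaker inhibitor, a lower number a stronger inhibitor. Compound 1 `OC[C@H]1O[C@@H](n2cnc3c(CSc4ccccc4F)ncnc32)[C@H](O)[C@@H]1O` gives 355 nM. Compound 2 `OC[C@H]1O[C@@H](n2cnc3c(CSc4ccc(Cl)c(Cl)c4)ncnc32)[C@H](O)[C@@H]1O` gives 224 nM. Compound 3 `OC[C@H]1O[C@@H](n2cnc3c(CSc4cccc(Br)c4)ncnc32)[C@H](O)[C@@H]1O` gives 363 nM, the highest of the three numbers, although its gaps to both others lie within the scatter. The three steps between them are all modest: a 1.6-fold lower number from compound 1 to compound 2 (0.20 log units; within the scatter), a 1.0-fold higher number from compound 1 to compound 3 (0.01 log units; within the scatter) and a 1.6-fold higher number from compound 2 to compound 3 (0.21 log units; within the scatter), each inside the usual scatter.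

Compound 4 `O=[N+]([O-])c1cccc(SCc2ncnc3c2ncn3[C@@H]2O[C@H](CO)[C@@H](O)[C@H]2O)c1` has not yet been measured. It differs from compound 3 by nitro in place of bromo on an aromatic carbon: a nitro in place of bromo on an aromatic carbon, meta to a large group, so that 3-bromophenyl becomes 3-nitrophenyl. Within the data shown here, none of the measured steps introduces a nitro group; what they do show is that exchanging one substituted phenyl for another has barely moved this assay. On that basis the expected step is a 1.1-fold higher number from compound 3 to compound 4 (0.04 log units; within the scatter), with no movement beyond the scatter. Compound 4 is therefore estimated at 400 nM, within a range from 150 nM to 1100 nM.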

Compound 4, half-maximal inhibitory concentration: 4.79 nM
Compound 4: the middle estimate sits 84-fold (1.92 log units) above what was measured; measured number outside the range, below it.
By their numbers in this assay, from the lowest: compound 4; then compounds 2, 1 and 3 (each within the scatter of the next).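

In this assay the change from bromo to nitro brings a 76-fold lower number from compound 3 to compound 4 (1.88 log units; beyond the scatter) at this place on the phenyl ring, so the group here can matter far more than compounds 1, 2 and 3 suggested. The 3-nitrophenyl group also stands clear of the other two phenyl groups, with a 47-fold lower number from compound 2 to compound 4 (1.67 log units; beyond the scatter) and with a 74-fold lower number from compound 1 to compound 4 (1.87 log units; beyond the scatter) while compounds 1, 2 and 3 stay within the scatter of one another. Nothing measured here says why nitro has this effect.

The compounds shown leave open whether this large step belongs to nitro alone or would also appear with a nitrile or a carboxylic acid in the same place. As far as these compounds go, compound 4 is the only one carrying nitro, so whether the group would do the same elsewhere on the ring also stays open.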